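A few compounds are considered here, and "the series" means these few. Any claim that something is new, unique, unknown or untested is made for them only; others in the source may bear on it.

Compound 1 `CC(C)(C)Cc1c(-c2ccc(F)cc2)sc(N)c1C(=O)c1ccc(Cl)cc1`: 9%
Compound 2 `CC(C)(C)Cc1c(-c2ccccc2)sc(N)c1C(=O)c1ccc(Cl)cc1`: 1%

In an assay on CHO cells for displacement of a labelled ligand from adenosine receptor A3 (Homo sapiens), read by scintillation counting, tested at 10 uM (on this read-out lower numbers stand for less inhibition and higher numbers for more inhibition at the one concentration tested (going by the name of the read-out)), compound 2 gives 1%, the lower of the two numbers measured. Compound 1 gives 9%. Going by the values given here, the one measured step, a number 8 percentage points lower from compound 1 to compound 2 (within the scatter), was within the scatter. Compound 3 `COc1ccc(-c2sc(N)c(C(=O)c3ccc(Cl)cc3)c2CC(C)(C)C)cc1` differs from compound 2 by methoxy in place of hydrogen on an aromatic carbon. Among the compounds with values here, no measured step covers a methoxy at this place, so only the low numbers of compound 1 and compound 2 guide the expectation: a step of a number 7 percentage points higher from compound 2 to compound 3 (within the scatter) of no clear direction beyond the scatter is expected. Compound 3 is estimated at 8%, between 0% and 25%.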

Compound 3, a percentage reported as inhibition, at one concentration (the size of the read-out at that concentration, not a potency): 2%
The estimate for compound 3 lay 6 percentage points above the measured number, and the stated range covers the measured number.
By their numbers in this assay, from the lowest: compounds 2, 3 and 1 (each within the scatter of the next).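

In this assay, methoxy in place of hydrogen on this aromatic carbon, para to a large group, gives a number 1 percentage points higher from compound 2 to compound 3 (within the scatter), and methoxy in place of fluoro gives a number 7 percentage points lower from compound 1 to compound 3 (within the scatter). A third group at this place thus leaves all the steps within the scatter, so hydrogen, fluoro and methoxy here cannot be told apart in this read-out. Nothing available bears on the reason for these numbers. On these data alone, whether an amine or a carboxylic acid on this carbon would move the number beyond the scatter stays open. So does whether any change elsewhere on the shared core would do so.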